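The source may hold more compounds than are shown below. What is called first, only, known or untested is meant among the compounds shown, and "the series" means these compounds.

Compound 3 `COc1cccc(C2(NC(=O)c3c(OC)cc(C(F)(F)F)cc3SC)CCCN(C)C2)c1` gives 110 nM in an assay on cells for inhibition of sodium- and chloride-dependent glycine transporter 1 (Homo sapiens) (on this read-out lower numbers stand for an effect already at smaller amounts and higher numbers for an effect only at larger amounts of compound), the highest of the three numbers measured: compound 1 `COc1cc(C(F)(F)F)cc(SC)c1C(=O)NC1(c2ccc(F)cc2)CCCN(C)C1` gives 26 nM and compound 2 `COc1cc(C(F)(F)F)cc(SC)c1C(=O)NC1(c2cccc(Cl)c2)CCCN(C)C1` gives 25 nM, so that a 4.2-fold higher number from compound 1 to compound 3 (0.63 log units; beyond the scatter) and a 4.4-fold higher number from compound 2 to compound 3 (0.64 log units; beyond the scatter), while a 1.0-fold lower number from compound 1 to compound 2 (0.02 log units; within the scatter). Compound 4 `COc1cc(C(F)(F)F)cc(SC)c1C(=O)NC1(c2cnccn2)CCCN(C)C1` differs from compound 3 by pyrazin-2-yl in place of 3-methoxyphenyl on a saturated ring carbon. Among the measured compounds shown here, none of the measured steps exchanges the ring of carbon only for a ring with two hetero atoms, so the only guidance is that the 3-methoxyphenyl group of compound 3 already sits at the weaker end of this small set. For compound 4 the expected step of a 1.8-fold higher number from compound 3 to compound 4 (0.26 log units; within the scatter) is therefore small and uncertain, leaning toward a higher number. Compound 4 is estimated at 200 nM, with a range from 60 nM to 700 nM.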

Compound 4, half-maximal effective concentration: 1670 nM
Estimate against measurement, compound 4: 8.4-fold (0.92 log units) below; the measured number lies above the stated range.
By their numbers in this assay, from the lowest: compounds 2 and 1 (each within the scatter of the next); then compound 3; then compound 4.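

Among the compounds shown here, replacing the benzene-type ring on this saturated ring carbon with a ring holding two hetero atoms is a much larger change in this assay than any seen among the earlier compounds. Pyrazin-2-yl gives (a 15-fold higher number from compound 3 to compound 4 (1.18 log units; beyond the scatter)), and the steps from the two more effective compounds are larger still (a 67-fold higher number from compound 2 to compound 4 (1.82 log units; beyond the scatter); a 64-fold higher number from compound 1 to compound 4 (1.81 log units; beyond the scatter)). Nothing measured here explains this loss of effect. Going by these compounds, whether a single ring nitrogen, as in pyridin-2-yl, would already cost this much remains open, as does the effect of moving the ring nitrogens, as in pyrimidin-5-yl.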